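This account rests on a few compounds, and the source may have more. Where it says the series, first, only, none or still open, it means among the compounds named here.

In a functional assay on SW1573 cells (Homo sapiens) for inhibition, read by sulforhodamine B assay, with a stated time of 48 h (a higher number here means a weaker inhibitor of growth, a lower number a stronger inhibitor of growth), compound 1, whose structure is `COC(=O)[C@@]1(C)CCC=C2[C@@H]1CC[C@@H](C)[C@]2(C)Cc1c[nH]c2ccccc12`, gives 7300 nM. Compound 2, with the structure `COC(=O)[C@@]1(C)CCC=C2[C@@H]1CC[C@@H](C)[C@]2(C)Cc1c[nH]c2ccc(C)cc12`, gives 15000 nM; it differs from compound 1 in one place: methyl in place of hydrogen on an aromatic carbon. That change made a step of a 2.1-fold higher number from compound 1 to compound 2 (0.31 log units; beyond the scatter) in this assay.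

Compound 3 has a different core, with the structure `COC(=O)[C@@]1(C)CC[C@@H]2C3=C1CC[C@@H](C)[C@]3(C)Cc1c2[nH]c2ccccc12`; how its core differs from that of compound 1 is not broken down here. In this assay, among the compounds with values here, compound 3 gives 8300 nM, a number within the usual scatter of the one for compound 1.

Compound 4, with the structure `COC(=O)[C@@]1(C)CC[C@@H]2C3=C1CC[C@@H](C)[C@]3(C)Cc1c2[nH]c2ccc(C)cc12`, has not yet been measured. It differs from compound 3 by methyl in place of hydrogen on an aromatic carbon. This is the same kind of change as from compound 1 to compound 2, though the ring carrying the methyl is here part of a fused or bridged system of five rings rather than of two rings.

Within the data shown here, compound 4 is expected to show a step of a 1.9-fold higher number from compound 3 to compound 4 (0.29 log units; within the scatter), set beside the earlier step of a 2.1-fold higher number from compound 1 to compound 2 (0.31 log units; beyond the scatter), because the only measured instance of this change, a 2.1-fold higher number from compound 1 to compound 2 (0.31 log units; beyond the scatter), raised the number modestly. For compound 4 the estimated value in this assay is 16000 nM, within a range from 7000 nM to 36000 nM.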

Compound 4, concentration for 50% growth inhibition: 15000 nM
Estimate against measurement, compound 4: 1.1-fold (0.03 log units) above; measured number inside the range.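

In this assay, methyl in place of hydrogen on an aromatic carbon gives a 1.8-fold higher number from compound 3 to compound 4 (0.26 log units; within the scatter) on the core of compound 3. Set beside the same change on the core of compound 1, the two steps point the same way and do not differ by more than the scatter, so in these two pairs the change carries from one core to the other: the same change on two cores in this assay, a 2.1-fold higher number (0.31 log units; beyond the scatter) from compound 1 to compound 2 and a 1.8-fold higher number (0.26 log units; within the scatter) from compound 3 to compound 4, 1.1-fold (0.06 log units) apart, within the scatter of two such steps. Within the data shown here, this is not a general rule, however: it rests on only two pairs, the step on the core of compound 3 cannot be told from scatter when taken alone, and the numbers give no reason for the change in either pair.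

The compounds shown carry only hydrogen or methyl at this place on the aromatic ring, so it remains open whether a chlorine atom, a methoxy group or a longer chain there would behave alike on both cores. All four compounds also keep the same methyl ester, which leaves open what a carboxylic acid or an amide in its place would do.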